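The source may report more compounds than this note shows. Statements on the series, on what has been measured and on what is new or still open speak of the compounds shown alone.

Working notes, series in an in vitro ADME assay on microsomes from liver (Mus musculus) for pharmacokinetics, read by LC-MS, with a stated time of 10 min, tested at 1 uM; a higher number here means faster removal of the compound, a lower number slower removal:

- compound 1 `CC(C)N1C[C@H](C(=O)Nc2ccc(Cl)cc2)[C@@H](c2ccc(/C=C/C(=O)Nc3ccccc3N)cc2)C1`: 38 mL/min/kg
- compound 2 `N#CCN1C[C@H](C(=O)Nc2ccc(Cl)cc2)[C@@H](c2ccc(/C=C/C(=O)Nc3ccccc3N)cc2)C1`: 51 mL/min/kg
- compound 3 `Nc1ccccc1NC(=O)/C=C/c1ccc([C@H]2CN(C3CCOCC3)C[C@@H]2C(=O)Nc2ccc(Cl)cc2)cc1`: not yet measured

Compound 2, at 51 mL/min/kg, stands level with compound 1 within the scatter. The next change leads to compound 3, with oxan-4-yl in place of cyanomethyl on an amine nitrogen in a ring.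

Among the compounds with values here, one measured step bears on this nitrogen: a 1.3-fold higher number from compound 1 to compound 2 (0.13 log units; within the scatter), with cyanomethyl in place of isopropyl. Within the data shown here, no measured compound carries oxan-4-yl, so that single step is a thin guide. Given that step, no change beyond the scatter is expected in this assay, in either direction.

The expected result is a 1.2-fold lower number from compound 2 to compound 3 (0.08 log units; within the scatter).

For compound 3 the estimate is 42 mL/min/kg, with an expected range of 21 mL/min/kg to 85 mL/min/kg.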

Compound 3, clearance: 44 mL/min/kg
Compound 3: middle estimate off by 1.0-fold (0.02 log units), on the low side, within the range that was stated.
By their numbers in this assay, from the lowest: compounds 1, 3 and 2 (each within the scatter of the next).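

Replacing cyanomethyl with oxan-4-yl on the amine nitrogen gives a 1.2-fold lower number from compound 2 to compound 3 (0.06 log units; within the scatter) in this assay, and replacing isopropyl with oxan-4-yl gives a 1.2-fold higher number from compound 1 to compound 3 (0.06 log units; within the scatter). The position now holds a ring substituent as well as two open-chain groups, and none of the three separates from the others beyond the scatter. Nothing available accounts for these level numbers.

From the compounds shown here alone, whether a carboxylic acid, a primary amine or a phenyl group on this nitrogen would move the number beyond the scatter remains open. Also open, going by these compounds, is whether removal in this assay responds more to other parts of the shared core, such as the (4-chlorophenyl)carbamoyl group, which is the same in all three compounds.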